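Extending the Amide Substituent from Compound 2 to Compound 4

This account rests on a few compounds, and the source may have more. Where it says the series, first, only, none or still open, it means among the compounds named here.

The series comprises three measured compounds sharing a common core. Compound 1 `C#CCN(Cc1ccc2nc(C)nc(O)c2c1)c1ccc(C(=O)N[C@@H](CCC(=O)O)C(=O)N2CCCC2C(=O)O)cc1` gives 35 nM in an assay on L1210 cells for inhibition of Thymidylate synthase (Mus musculus); on this read-out higher numbers stand for weaker inhibition and lower numbers for stronger inhibition. Compound 3 `C#CCN(Cc1ccc2nc(C)nc(O)c2c1)c1ccc(C(=O)N[C@@H](CC(C)C(=O)O)C(=O)N[C@@H](CCC(=O)O)C(=O)O)cc1` gives 8.6 nM in this assay. Compound 2 `C#CCN(Cc1cc2c(O)nc(C)nc2cc1C)c1ccc(C(=O)N[C@@H](CCC(=O)O)C(=O)N(C)[C@@H](CCC(=O)O)C(=O)O)c(F)c1` gives 1.1 nM in this assay, which is the lowest of the three numbers: the gap to compound 3 lies beyond the scatter, and the gap to compound 1 is wider still. Compound 2 thus shows the strongest inhibition within this small set.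

Compound 4 `C#CCN(Cc1cc2c(O)nc(C)nc2cc1C)c1ccc(C(=O)N[C@@H](CCC(=O)O)C(=O)N(CC)[C@@H](CCC(=O)O)C(=O)O)c(F)c1` has not yet been measured in this assay. It differs from compound 2 at a single position: methyl in place of hydrogen on a saturated chain carbon bound to an amide-type nitrogen. Read one bond further out, the change turns methyl into ethyl on the (1,3-dicarboxypropyl)amino group.

Among the measured compounds shown here, no step between two measured compounds isolates this particular change, so the expectation rests on the small size of what enters. The author expects the step of a 1.5-fold higher number from compound 2 to compound 4 (0.16 log units; within the scatter) to be small, in the direction of slightly weaker inhibition, and likely within the scatter of the measurement. On that basis compound 4 is estimated at 1.6 nM in this assay, with a range from 0.6 nM to 4.5 nM.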

Compound 4, inhibition constant: 0.35 nM
Beside the measured number, compound 4's estimate is 4.6-fold (0.66 log units) above it, outside the stated range (below it).
By their numbers in this assay, from the lowest: compound 4; then compound 2; then compound 3; then compound 1.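

In this assay, the added methyl on a saturated chain carbon bound to an amide-type nitrogen gives a 3.1-fold lower number from compound 2 to compound 4 (0.50 log units; beyond the scatter), a modest step that lies beyond the scatter and points towards stronger inhibition. Among the compounds shown here, this is the first pair that differs in one place, so it shows for the first time that this position responds to a change as small as methyl to ethyl, and that the (1,3-dicarboxypropyl)(ethyl)amino group gives a lower number than the (1,3-dicarboxypropyl)(methyl)amino group on this core. Nothing available here accounts for the direction or size of this step.

The compounds shown leave open whether a longer chain such as propyl on the same nitrogen would extend this step, hold it or reverse it, and whether an amine or a carboxylic acid at the end of the ethyl chain would keep the lower number. They also leave open whether the same change would give a step of similar size on the other cores in the series, since this single pair is the only one that bears on it.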